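Solubility notes: isobutyl to 2-hydroxyethyl on the shared core

The compounds below may be only part of what the source reports. "The series", "measured", "known", "first", "only" and "open" are said of these compounds alone.

Among the compounds with values here, in a physicochemical assay for solubility (on this read-out higher numbers stand for higher solubility and lower numbers for lower solubility), compound 3 `CNC(=O)c1cc(C(=O)NCC(C)C)cn(Cc2ccccc2)c1=O` gives 43 ug/mL, the only true number in this set. Compound 1 `CNC(=O)c1cc(C(=O)NCCCC2CNCCO2)cn(Cc2ccccc2)c1=O` reads >= 194 ug/mL, which is a limit of the assay. Compound 2 `CNC(=O)c1cc(C(=O)NC)c(=O)n(Cc2ccccc2)c1` reads >= 118 ug/mL, also a limit.

Compound 4 `CNC(=O)c1cc(C(=O)NCCO)cn(Cc2ccccc2)c1=O`, not yet measured, differs from compound 3 as follows: hydroxymethyl in place of isopropyl on a saturated chain carbon bound to an amide-type nitrogen. Hydroxymethyl stands in place of isopropyl on a saturated chain carbon bound to an amide-type nitrogen.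

Within the data shown here, two measured steps bear on this change: an at least 4.5-fold lower number from compound 1 to compound 3 (0.65 log units; beyond the scatter) and an at least 2.7-fold lower number from compound 2 to compound 3 (0.43 log units; beyond the scatter). Both lie beyond the scatter and leave compound 3 lowest of the three. A rise in this assay is therefore expected, and the estimated step is a 3.0-fold higher number from compound 3 to compound 4 (0.48 log units; beyond the scatter). For compound 4 the estimate is 130 ug/mL, with an expected range of 60 ug/mL to 280 ug/mL.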

Compound 4, solubility: >= 140 ug/mL
Compound 4: no number, only a limit (the forecaster's own chance of this, stated with the estimate: 45%); middle value at least 1.0-fold (0.03 log units) from the limit.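

With isobutyl changed to 2-hydroxyethyl, a change that brings in no ring, this assay shows an at least 3.2-fold higher number from compound 3 to compound 4 (0.51 log units; beyond the scatter), so compound 3 also stands lowest against a side chain without the morpholin-2-yl ring of compound 1. Compound 4 gives only a limit of the assay, not a number: the limit of >= 140 ug/mL in this assay, at which 1 of the 4 values shown sits. The steps between compound 4 and compound 1 and between compound 4 and compound 2 join limit to limit and cannot be read.

From the compounds shown here alone, how far compound 4 lies past its limit stays open. Also open, going by these compounds, is whether an amine or a carboxylic acid in place of the hydroxy group on this chain would give a true number in this assay.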